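The compounds below may be only part of what the source reports. "The series", "measured", "known", "first", "only" and "open" are said of these compounds alone.

Working notes on the series. Among the measured compounds shown here, in an in vitro ADME assay on microsomes from liver (Homo sapiens) for metabolic stability, read by HPLC (a higher number here means faster removal of the compound, a lower number slower removal), compound 1 `NC(=O)[C@@H](CCC(F)(F)F)N(CC1CCCC1)S(=O)(=O)c1ccc(Cl)cc1` gives 229 mL/min/kg and compound 2 `NC(=O)[C@@H](CCC(F)(F)F)N(CC1CCOCC1)S(=O)(=O)c1ccc(Cl)cc1` gives 114 mL/min/kg, so compound 2 stands within the scatter of the only other measured number. The next structure is compound 3 `NC(=O)[C@@H](CCC(F)(F)F)N(C[C@H]1COCCO1)S(=O)(=O)c1ccc(Cl)cc1`, with this change: 1,4-dioxan-2-yl in place of oxan-4-yl on a saturated chain carbon bound to a sulfonamide nitrogen. In words, 1,4-dioxan-2-yl takes the place of oxan-4-yl on a saturated chain carbon bound to a sulfonamide nitrogen. For the measured compounds named here, one measured step bears on this, the swap at the same place of oxan-4-yl for cyclopentyl: a 2.0-fold lower number from compound 1 to compound 2 (0.30 log units; within the scatter). That step lies within the scatter, and a single pair gives thin support for any trend. In this assay, a modest shift toward a lower number is therefore expected, not clearly beyond the scatter. The expected step is a 1.4-fold lower number from compound 2 to compound 3 (0.15 log units; within the scatter). Compound 3 is estimated at 80 mL/min/kg, with an expected range of 40 mL/min/kg to 160 mL/min/kg.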

Compound 3, clearance: 176 mL/min/kg
Compound 3: the middle estimate sits 2.2-fold (0.34 log units) below what was measured; measured number above the stated range.
By their numbers in this assay, from the lowest: compounds 2, 3 and 1 (each within the scatter of the next).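

In this assay, 1,4-dioxan-2-yl in place of oxan-4-yl on a saturated chain carbon bound to a sulfonamide nitrogen gives a 1.5-fold higher number from compound 2 to compound 3 (0.19 log units; within the scatter) and, in place of cyclopentyl, gives a 1.3-fold lower number from compound 1 to compound 3 (0.11 log units; within the scatter). Among the compounds shown here, all three rings at this place now lie within the scatter of one another, and a second ring oxygen does not extend the single earlier step into a trend with the count of ring oxygens. Nothing available explains this result.

The compounds shown leave open whether an amine in the ring, as in piperidin-4-yl, or an open-chain ether at this place would give a step beyond the scatter. They also leave open how the opposite configuration at the defined stereocentre of 1,4-dioxan-2-yl would read.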